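A few compounds are considered here, and "the series" means these few. Any claim that something is new, unique, unknown or untested is made for them only; others in the source may bear on it.

Compound 1 `CCOc1nc(N)nc2c1ncn2/C=C1/CC1(CO)CO`: > 20000 nM (a limit)
Compound 2 `CC(C)Nc1nc(N)nc2c1ncn2/C=C1/CC1(CO)CO`: > 24000 nM (a limit)

In an ADME assay on Akata cells (Homo sapiens) for cytotoxicity, with a stated time of 7 days (a higher number here means that more compound is tolerated, a lower number that less compound is tolerated), compound 2 gives > 24000 nM, which is a limit of the assay and not a number. Among the measured compounds shown here, compound 1, the only other compound measured, also gives just a limit, > 20000 nM. Compound 2 therefore has no exact place on this scale.

The next compound is compound 3 `CCCNc1nc(N)nc2c1ncn2/C=C1/CC1(CO)CO`. Its change is small: propyl in place of isopropyl on a nitrogen on an aromatic ring. The two groups have the same atoms, joined differently.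

For the measured compounds named here, the one measured step is a step that the two limits leave unreadable from compound 1 to compound 2. It places isopropylamino where ethoxy stood on an aromatic carbon, so it is a different change, and it offers no size to carry over. With compound 2 at > 24000 nM as the closest guide, no step beyond the scatter is expected in this assay, and another limit is the likeliest report. The expected change is a step that the limit leaves unreadable from compound 2 to compound 3. For compound 3 the estimate is 30000 nM, with an expected range from 12000 nM to 100000 nM.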

Compound 3, half-maximal cytotoxic concentration: > 24000 nM
Compound 3: no number, only a limit (the forecaster's own chance of this, stated with the estimate: 75%); the middle value lies beyond the limit too.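

Compound 3, like compound 1 and compound 2, gives only a limit of the assay and not a number, so none of the steps among these three compounds can be read. The compounds shown leave open where each one's half-maximal cytotoxic concentration actually lies in this assay, and whether propyl in place of isopropyl changes it at all.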